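Swapping a Second Chloro for Methyl on the Aryl Ring

The compounds below may be only part of what the source reports. "The series", "measured", "known", "first", "only" and "open" are said of these compounds alone.

Compound 1 `OC1CCN(c2ccc(-c3ccc(Cl)cc3Cl)nn2)CC1` is one of two compounds tested in a functional assay on the whole organism with Mus musculus as the target (on this read-out lower numbers stand for an effect already at smaller amounts and higher numbers for an effect only at larger amounts of compound), where compound 1 gives 8.5 mg/kg, the lowest of the two numbers. Its nearest neighbour is compound 2 `Cc1ccc(-c2ccc(N3CCC(O)CC3)nn2)c(Cl)c1`, which gives 17 mg/kg; the step of a 2.0-fold higher number from compound 1 to compound 2 (0.30 log units; within the scatter) is the same kind of exchange, made elsewhere on the same ring. Compound 3 `Cc1cc(Cl)ccc1-c1ccc(N2CCC(O)CC2)nn1` differs from compound 1 by methyl in place of chloro on an aromatic carbon. Among the compounds with values here, because the only comparable step, a 2.0-fold higher number from compound 1 to compound 2 (0.30 log units; within the scatter), stayed within the scatter, no shift beyond the scatter is expected for compound 3 in this assay, with an expected step of a 1.4-fold higher number from compound 1 to compound 3 (0.15 log units; within the scatter). Compound 3 is estimated at 12 mg/kg, ranging from 5 mg/kg to 30 mg/kg.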

Compound 3, dose for half-maximal effect: 10 mg/kg
Estimate against measurement, compound 3: 1.2-fold (0.08 log units) above; the measured number falls inside the stated range.
By their numbers in this assay, from the lowest: compounds 1, 3 and 2 (each within the scatter of the next).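

In this assay, methyl in place of chloro on the aromatic carbon ortho to a large group gives a 1.2-fold higher number from compound 1 to compound 3 (0.07 log units; within the scatter), so the exchange stays within the scatter at this position too. Alongside a 2.0-fold higher number from compound 1 to compound 2 (0.30 log units; within the scatter), made elsewhere on the same ring, neither chloro group of compound 1 shows a measurable loss when it is exchanged for methyl. No measured property is available to explain this result. Still open, on these data alone, is whether an amine or a carboxylic acid at this position would move the number beyond the scatter.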